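Two ring stereocentres inverted in an endoperoxide acid

The compounds below may be only part of what the source reports. "The series", "measured", "known", "first", "only" and "open" are said of these compounds alone.

The study concerns endoperoxide acids measured in a functional assay on HOP-92 cells (Homo sapiens) for inhibition; a higher number here means a weaker inhibitor of growth, a lower number a stronger inhibitor of growth. Compound 1 `C=C1CCC[C@H]2[C@](C)(CC[C@]3(C)CC[C@H]([C@@H](C)C(=O)O)OO3)[C@@H](C)CC[C@]12C` gives 290 nM in this assay. Compound 2 `C=C1CCC[C@H]2[C@](C)(CCC(C)=O)[C@@H](C)CC[C@]12C` reaches only the limit of > 15000 nM in this assay, so no number is known for it. Compound 3 `C=C1CCCC(C)(C)C1CC[C@@]1(C)CC[C@H]([C@@H](C)C(=O)O)OO1` gives 2230 nM in this assay, which is the highest of the two numbers in hand; compound 1 sits a good way lower, beyond the usual scatter of this assay. No pair among the measured compounds differs in a single place, so no measured step is available, and the one limit shown, (the limit of > 15000 nM in this assay, at which 1 of the 3 values shown sits), gives no cause for any difference.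

Compound 4 `C=C1CCCC(C)(C)C1CC[C@]1(C)CC[C@@H]([C@@H](C)C(=O)O)OO1` has not yet been measured. It differs from compound 3 as follows: the two compounds have the same atoms and bonds; at least one stereo element is drawn with a configuration in one of them and without one in the other: 2 of 4 stereo elements differ; a stereocentre at a saturated ring carbon is drawn S in compound 3 and R in compound 4; a stereocentre at a saturated ring carbon is drawn R in compound 3 and S in compound 4. With no measured change of this kind to guide the size, the author expects for compound 4 a step of a 1.5-fold lower number from compound 3 to compound 4 (0.17 log units; within the scatter) in this assay, a value of 1500 nM, estimated between 300 nM and 8000 nM.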

Compound 4, concentration for 50% growth inhibition: 6630 nM
Compound 4: the middle estimate sits 4.4-fold (0.65 log units) below what was measured, and the stated range covers the measured number.
By their numbers in this assay, from the lowest: compound 1; then compound 3; then compound 4. At a limit, above all of these: compound 2.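

Inverting the two saturated ring stereocentres while the atoms and bonds stay the same gives a 3.0-fold higher number from compound 3 to compound 4 (0.47 log units; beyond the scatter) in this assay. Going by these compounds alone, as the only measured step, it shows that the drawn configuration at these ring carbons alone can shift growth inhibition beyond the usual scatter, with the lower number belonging to compound 3. One caution applies to reading this step as a clean inversion: the fact that one of compounds 3 and 4 is drawn with a defined configuration and the other without, at the place where they differ

Both stereocentres change together, so the compounds shown do not separate the contribution of each one or show what a single inversion would do. They also leave open whether the same inversion would matter if a methyl ester or an amide replaced the carboxylic acid.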